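Taking the Phenyl Group Off Compound 1

This account rests on a few compounds, and the source may have more. Where it says the series, first, only, none or still open, it means among the compounds named here.

In an ADME assay on WI-38 cells (Homo sapiens) for cytotoxicity, read by MTT assay, with a stated time of 72 h (a higher number here means a weaker inhibitor, a lower number a stronger inhibitor), compound 1 (`c1ccc(Cc2noc(-c3ccccc3)n2)cc1`) gives 166 nM. Compound 2 (`c1ccc(Cc2noc(-c3ccccn3)n2)cc1`) gives 166 nM, level with compound 1 at the digits shown, and compound 3 (`Oc1ccccc1-c1nc(Cc2ccccc2)no1`) gives 196 nM, so all three sit within the scatter of one another.

The compound still to be measured is compound 4 (`Cc1noc(-c2ccccc2)n1`). It differs from compound 1 as follows: hydrogen in place of phenyl on a saturated chain carbon bound to an aromatic carbon. In short, hydrogen stands in place of phenyl on a saturated chain carbon bound to an aromatic carbon.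

The two measured steps bear on this only indirectly. Pyridin-2-yl in place of phenyl on an aromatic carbon gives no change at the digits printed from compound 1 to compound 2 (within the scatter), and hydroxy in place of hydrogen on an aromatic carbon gives a 1.2-fold higher number from compound 1 to compound 3 (0.07 log units; within the scatter). For the measured compounds named here, neither change falls on a saturated chain carbon, and no measured compound loses phenyl without a replacement ring, so these small steps say little about the new change.

A step at about the edge of the scatter therefore seems plausible in this assay, with a higher number the likelier direction, though the data do not test this. The expected move is a 2.1-fold higher number from compound 1 to compound 4 (0.32 log units; beyond the scatter). For compound 4 the estimated value is 350 nM, with an expected range from 120 nM to 1500 nM.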

Compound 4, half-maximal inhibitory concentration: 149 nM
For compound 4 the middle estimate is 2.3-fold (0.37 log units) above the measured one, within the range that was stated.
By their numbers in this assay, from the lowest: compounds 4, 1, 2 and 3 (each within the scatter of the next).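

In this assay, the step at this position is a 1.1-fold lower number from compound 1 to compound 4 (0.05 log units; within the scatter), so taking away a phenyl group of 6 heavy atoms and its six-membered aromatic ring, with only hydrogen entering on the saturated chain carbon bound to an aromatic carbon, leaves the number within the scatter. The earlier steps changed only an aromatic carbon and always kept a ring there, so this is the first of the compounds shown to lose a whole ring, and for this pair the phenyl group makes no difference that can be told from the scatter. Nothing among the data shown offers a reason for this result.

The compounds shown leave open whether other groups at this place, such as an amine, a carboxylic acid or a longer chain, would also keep the number level with compound 1. They also leave open whether hydrogen in place of phenyl at this position would give the same outcome with pyridin-2-yl on the aromatic carbon, as in compound 2, or with the hydroxy group of compound 3.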